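The source may hold more compounds than are shown below. What is called first, only, known or untested is meant among the compounds shown, and "the series" means these compounds.

Compound 1 `CNc1nc(SCc2nc3ccccc3[nH]2)nc(-c2ccccc2)c1C#N` gives 12.5 nM in a functional assay on G-361 cells (Homo sapiens) for cytotoxicity, read by MTT assay, with a stated time of 3 days; a higher number here means a weaker inhibitor, a lower number a stronger inhibitor. Compound 2 `N#Cc1c(Nc2ccccn2)nc(SCc2nc3ccccc3[nH]2)nc1-c1ccccc1` gives 8.9 nM in this assay.

Compound 2 holds the lowest of the two numbers, with compound 1 nearest at a gap within the scatter. Compound 3 `N#Cc1c(NC(N)=S)nc(SCc2nc3ccccc3[nH]2)nc1-c1ccccc1` differs from compound 2 by a group of 3 heavy atoms (1 carbon, 1 nitrogen, 1 sulfur; no ring) in place of a group of 6 heavy atoms (5 carbon, 1 nitrogen; one six-membered aromatic ring with 1 hetero atom), on a nitrogen on an aromatic ring. Among the compounds with values here, the only measured step at that nitrogen, a 1.4-fold lower number from compound 1 to compound 2 (0.15 log units; within the scatter), stayed within the scatter, so the group on that nitrogen has so far made little difference. A further change there is expected to move this assay little, if at all, beyond the scatter. Compound 3 is therefore estimated at 12 nM, between 4 nM and 40 nM. Within the data shown here, the expected step of a 1.3-fold higher number from compound 2 to compound 3 (0.13 log units; within the scatter) is small and carries wide uncertainty, as no measured pair carries this group.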

Compound 3, half-maximal inhibitory concentration: 5.81 nM
Compound 3: middle estimate off by 2.1-fold (0.32 log units), on the high side; the measured number falls inside the stated range.
By their numbers in this assay, from the lowest: compounds 3, 2 and 1 (each within the scatter of the next, the first and the last beyond it).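

In this assay, within the data shown here, the group of 3 heavy atoms on the nitrogen gives the first step at this position beyond the scatter, though a modest one (a 2.2-fold lower number from compound 1 to compound 3 (0.33 log units; beyond the scatter)). Set against the pyridin-2-yl of compound 2, the same group stays within the scatter (a 1.5-fold lower number from compound 2 to compound 3 (0.19 log units; within the scatter)), so among these compounds a ring on this nitrogen is not required for numbers of this size. No measurement shown accounts for either step.

From the compounds shown here alone, whether a longer alkyl chain or a urea on that nitrogen would keep these numbers remains open. So does whether a carboxylic acid there would shift them.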